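Swapping the Aryl Group on an Aromatic Nitrogen

A few compounds are considered here, and "the series" means these few. Any claim that something is new, unique, unknown or untested is made for them only; others in the source may bear on it.

Measured in a functional assay on MCF7 cells (Homo sapiens) for antiproliferative activity, read by MTT assay, with a stated time of 48 h; on this read-out higher numbers stand for weaker inhibition and lower numbers for stronger inhibition:
compound 1, `N#CC1=C(N)Oc2c(N)cc3nc4ccccc4nc3c2C12C(=O)N(Cc1cnnn1-c1cccc(C(F)(F)F)c1)c1ccccc12`, gives 31600 nM.
compound 2, `CC(=O)Nc1ccc(-n2nncc2CN2C(=O)C3(C(C#N)=C(N)Oc4c(N)cc5nc6ccccc6nc5c43)c3ccccc32)cc1`, reaches only the limit > 50000 nM.
compound 3, `CCc1cccc(CC)c1-n1nncc1CN1C(=O)C2(C(C#N)=C(N)Oc3c(N)cc4nc5ccccc5nc4c32)c2ccccc21`, reaches only the limit > 50000 nM.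

Compound 3 thus stands at the limit of this assay, where (the limit of > 50000 nM in this assay, at which 2 of the 3 values shown sit), and no number is known for it. Compound 4, `N#CC1=C(N)Oc2c(N)cc3nc4ccccc4nc3c2C12C(=O)N(Cc1cnnn1-c1ccc(Cl)cc1Cl)c1ccccc12`, has not yet been measured. It differs from compound 3 as follows: 2,4-dichlorophenyl in place of 2,6-diethylphenyl on an aromatic nitrogen. The measured steps that bear on such aryl exchanges are an at least 1.5-fold higher number from compound 1 to compound 3 (0.19 log units; that floor lies within the scatter), an at least 1.5-fold higher number from compound 1 to compound 2 (0.19 log units; that floor lies within the scatter) and a step that the two limits leave unreadable from compound 2 to compound 3. Two of the three compounds sit at the limit, and the one step that reaches from a number to a limit has a floor that lies within the scatter, so no readable step beyond the scatter has been shown for any aryl exchange at this position. Compound 4 is therefore expected to give a value close to the limit, with a fair chance that this assay again reports only a limit; the estimate for compound 4 is 45000 nM, in a range from 15000 nM to 150000 nM. The expected step from compound 3 is an at least 1.1-fold lower number from compound 3 to compound 4 (0.04 log units; that floor lies within the scatter), that is, none beyond the scatter.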

Compound 4, half-maximal inhibitory concentration: > 50000 nM
Compound 4: a limit, no number; the forecaster's own chance of this, stated with the estimate: 55%; middle value at least 1.1-fold (0.04 log units) from the limit.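

In this assay compound 4 gives > 50000 nM, which is a limit and not a number. With its 2,4-dichlorophenyl group, the only aryl group shown that carries chlorine, compound 4 joins compound 2 and compound 3 at the limit, leaving compound 1 with its 3-(trifluoromethyl)phenyl group as the only compound with a number: the limit of > 50000 nM in this assay, at which 3 of the 4 values shown sit. For the compounds shown here, the only step to compound 4 that can be read is an at least 1.5-fold higher number from compound 1 to compound 4 (0.19 log units; that floor lies within the scatter), so this exchange too shows no difference beyond the scatter, and the steps that join compound 4 to compound 2 and to compound 3 cannot be read.

As far as these compounds go, it remains open how far compound 2, compound 3 and compound 4 lie from the limit, and whether they differ from one another at all. It also remains open whether an amine or a carboxylic acid on the phenyl ring, or a longer chain in place of the aryl group on the aromatic nitrogen, would give a number clearly lower than any shown here.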